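Swapping an Ester for an Oxadiazole on a Shared Core

The source may report more compounds than this note shows. Statements on the series, on what has been measured and on what is new or still open speak of the compounds shown alone.

Measured compounds:
- compound 1 `CCOC(=O)c1nc(C)c2c(c1N)C(=O)N(Cc1ccccc1)C2=O`: < 5000 nM
- compound 2 `Cc1nc(C(N)=O)c(N)c2c1C(=O)N(Cc1ccccc1)C2=O`: < 5000 nM
- compound 3 `CNC(=O)c1nc(C)c2c(c1N)C(=O)N(Cc1ccccc1)C2=O`: 41000 nM

In a physicochemical assay for solubility, using the shake flask method, in simulated intestinal fluid, measured as kinetic solubility, with a stated time of 2 h, at 25 degrees C, at pH 6.5 (a higher number here means a more soluble compound, a lower number a less soluble compound), compound 1 gives < 5000 nM, which is a limit of the assay rather than a number. Compound 2 also sits at a limit, < 5000 nM. Compound 3 gives a readable number, 41000 nM. Two of the three values therefore sit at the limit of < 5000 nM in this assay, at which 2 of the 3 values shown sit, so compound 1 stands among the least soluble of the three, though how far below compound 3 it lies cannot be read. Within the data shown here, the step of an at least 8.2-fold higher number from compound 1 to compound 3 (0.91 log units; beyond the scatter) is the one readable change from compound 1; the step that the two limits leave unreadable from compound 1 to compound 2 remains unreadable.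

Compound 4 `Cc1nnc(-c2nc(C)c3c(c2N)C(=O)N(Cc2ccccc2)C3=O)o1` changes compound 1 in one place: 5-methyl-1,3,4-oxadiazol-2-yl in place of ethoxycarbonyl on an aromatic carbon. Among the measured compounds shown here, no measured step makes this exact change, though both measured steps alter the same ethoxycarbonyl group, and only the methylamino replacement lifted the value clearly. Since the oxadiazole brings no hydrogen-bond donor and keeps a similar size, the expectation is a step that the limit leaves unreadable from compound 1 to compound 4, likely still near the limit. Compound 4 is estimated at 4000 nM, with a range from 800 nM to 25000 nM.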

Compound 4, solubility: < 5000 nM
Compound 4: no number, only a limit; the forecaster's own chance of this, stated with the estimate: 55%; the middle value does not contradict the limit.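

On this aromatic carbon, next to the ring nitrogen and ortho to the amino group, exchanging methylcarbamoyl for 5-methyl-1,3,4-oxadiazol-2-yl gives, in this assay, an at least 8.2-fold lower number from compound 3 to compound 4 (0.91 log units; beyond the scatter). Compound 4 gives < 5000 nM, which is a limit of the assay and not a number, so the steps to it from compound 1 and from compound 2 cannot be read. Methylcarbamoyl therefore remains the only one of the four groups shown at this carbon with a readable value, and the other three cannot be ranked against one another: the limit of < 5000 nM in this assay, at which 3 of the 4 values shown sit.

The compounds shown leave open how far apart compound 1, compound 2 and compound 4 really lie, since a shared limit hides any difference between them. They also leave open whether a longer chain on the amide nitrogen, such as ethyl, or a carboxylic acid at this carbon would give a readable value like that of compound 3 or would stay at the limit.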